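A few compounds are considered here, and "the series" means these few. Any claim that something is new, unique, unknown or untested is made for them only; others in the source may bear on it.

Of the compounds shown here, three on a shared core have been tested in a functional assay on the whole organism for positive allosteric modulation, with Mus musculus as the target; on this read-out higher numbers stand for an effect only at larger amounts of compound and lower numbers for an effect already at smaller amounts: compound 1 `CCC(=O)N(c1ccc(OC)cc1)C1CCCC1N(C)C`, compound 2 `CCC(=O)N(c1ccc(C)cc1)C1CCCC1N(C)C` and compound 3 `CCC(=O)N(c1ccc(F)cc1)C1CCCC1N(C)C`. Compound 3 stands at > 50 mg/kg, which is a limit of the assay and not a number. Compound 1 gives > 50 mg/kg; > 50 mg/kg (2 entries), which is likewise a limit. Only compound 2 gives a number, 10 mg/kg; 10 mg/kg (2 entries), so the position of compound 3 on this scale is known from one side only.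

The next compound, compound 4 `CCC(=O)N(c1ccc(F)c(Cl)c1)C1CCCC1N(C)C`, comes from compound 3 through a single structural change, chloro in place of hydrogen on an aromatic carbon, ortho to a fluoro group and meta to a large group. Within the data shown here, no pair of tested compounds differs in one place only, so the data do not show directly what such a change does in this assay.

A modest step towards a smaller dose is expected, though it may stay within the scatter. Compound 2, at 10 mg/kg; 10 mg/kg (2 entries), shows that this core can reach a measurable dose. The estimated change is an at least 1.2-fold lower number from compound 3 to compound 4 (0.09 log units; that floor lies within the scatter). For compound 4 the expected value is 40 mg/kg, with an estimated range of 12 mg/kg to 100 mg/kg.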

Compound 4, dose for half-maximal effect: 0.7 mg/kg
The estimate for compound 4 lay 57-fold (1.76 log units) above the measured number; measured number below the stated range.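

On the shared core, the aromatic carbon ortho to a fluoro group and meta to a large group proves to be a place where a single added atom counts heavily in this assay: chloro in place of hydrogen brings an at least 71-fold lower number from compound 3 to compound 4 (1.85 log units; beyond the scatter). Before this result, no pair of compounds differing in one place had given a step in this assay, so this is the first direct reading of what one such change does, and it lies well beyond the scatter. The step has no upper end, because the value of compound 3 is a limit and not a number: the limit of > 50 mg/kg in this assay, at which 1 of the 4 values shown sits.

Going by these compounds, whether this gain belongs to chloro itself or would also come with another group at the same place, such as bromo or nitrile, remains open. Also open is whether chloro needs the fluoro group to act in this way, since the only chloro compound shown carries both groups, and the step says nothing about chloro placed beside the groups of compound 1 or compound 2.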